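The source may hold more compounds than are shown below. What is called first, only, known or untested is meant among the compounds shown, and "the series" means these compounds.

Within the data shown here, compound 2, drawn as `CCN(CC)CCNC(=O)c1ccc(C(CC)(CC)c2ccc(OCC(O)C(C)(C)C)c(C)c2)n1CC`, is one of two compounds measured in an assay on HL-60 cells for agonist activity at vitamin D3 receptor (Homo sapiens), read by microscopy, with a stated time of 96 h (on this read-out lower numbers stand for an effect already at smaller amounts and higher numbers for an effect only at larger amounts of compound), where compound 2 gives 110 nM. Its only companion so far is compound 1, drawn as `CCN(CC)CCNC(=O)c1ccc(C(CC)(CC)c2ccc(OCC(=O)C(C)(C)C)c(C)c2)n1CC`, which in this assay gives 91 nM. The two differ in one place, and the step of a 1.2-fold higher number from compound 1 to compound 2 (0.08 log units; within the scatter) is too small to separate them; compound 2 thus has the higher of two numbers that cannot be told apart.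

Compound 3, drawn as `CCn1c(C(=O)NCC(OC)OC)ccc1C(CC)(CC)c1ccc(OCC(O)C(C)(C)C)c(C)c1`, changes a different part of the molecule: dimethoxymethyl in place of (diethylamino)methyl on a saturated chain carbon bound to an amide-type nitrogen. Among the measured compounds shown here, no measured step touches this position, since the single step, from compound 1 to compound 2, concerns the chain on the aromatic oxygen and left the rest of the structure unchanged. For the measured compounds named here, the expectation for compound 3 therefore rests on no direct precedent, and a step of about a 1.6-fold higher number from compound 2 to compound 3 (0.21 log units; within the scatter) is estimated, with a wide margin in either direction. On that basis compound 3 is expected to give about 180 nM in this assay, most likely between 50 nM and 700 nM.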

Compound 3, half-maximal effective concentration: 150 nM
Compound 3: middle estimate off by 1.2-fold (0.08 log units), on the high side; the measured number falls inside the stated range.
By their numbers in this assay, from the lowest: compounds 1, 2 and 3 (each within the scatter of the next).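

Among these compounds, this is the first measured step at the saturated chain carbon bound to an amide-type nitrogen, and it comes from a large exchange: in this assay, dimethoxymethyl in place of (diethylamino)methyl gives a 1.4-fold higher number from compound 2 to compound 3 (0.13 log units; within the scatter). The nitrogen of the leaving group is gone and two oxygens have entered, yet the two numbers cannot be told apart, so for this pair the diethylamino nitrogen is not required for a number in the same range. No supporting measurement is available to explain this outcome.

The compounds shown leave open whether this position tolerates other kinds of group, such as a carboxylic acid or a longer chain, or whether one of these would move the number clearly beyond the scatter. Going by these compounds, it also remains open whether the same exchange would give a similar result in compound 1, which carries (tert-butyl)carbonyl on the chain at the aromatic oxygen, as this step was read only in the presence of the 1-hydroxy-2,2-dimethylpropyl group.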